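Chloro to trifluoromethyl on the terminal urea aryl ring

This account rests on a few compounds, and the source may have more. Where it says the series, first, only, none or still open, it means among the compounds named here.

Measured so far:
compound 1 `O=C(Nc1cccc(-n2cc(-c3ccncc3)c(-c3ccc(Cl)c(O)c3)n2)c1)Nc1ccc(Cl)c(Cl)c1`: > 32500 nM
compound 2 `O=C(Nc1cccc(-n2cc(-c3ccncc3)c(-c3ccc(Cl)c(O)c3)n2)c1)Nc1cc(C(F)(F)F)cc(C(F)(F)F)c1`: 5390 nM
compound 3 `COc1cc(-c2nn(-c3cccc(NC(=O)Nc4cccc(C(F)(F)F)c4)c3)cc2-c2ccncc2)ccc1Cl`: 4730 nM

In a functional assay on NCI-H322M cells (Homo sapiens) for inhibition, read by sulforhodamine B assay, with a stated time of 48 h (a higher number here means a weaker inhibitor of growth, a lower number a stronger inhibitor of growth), compound 1 reaches only (the limit of > 32500 nM in this assay, at which 1 of the 3 values shown sits), a limit and not a number. Compound 2 gives 5390 nM in this assay and compound 3 gives 4730 nM; these two lie within the usual scatter of each other. Compound 4 `O=C(Nc1cccc(-n2cc(-c3ccncc3)c(-c3ccc(Cl)c(O)c3)n2)c1)Nc1ccc(Cl)c(C(F)(F)F)c1` is not yet measured. It differs from compound 1 by trifluoromethyl in place of chloro on an aromatic carbon. Among the measured compounds shown here, no step between measured compounds is available here, so the size of the change is open. Both compound 2 and compound 3 carry a trifluoromethyl group on that ring and return measurable numbers, which supports an expected move toward stronger inhibition. The expected step is an at least 3.6-fold lower number from compound 1 to compound 4 (0.55 log units; beyond the scatter). Compound 4 is estimated at 9000 nM, with a range from 3000 nM to 32500 nM.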

Compound 4, concentration for total growth inhibition: 4480 nM
Compound 4: middle estimate off by 2.0-fold (0.30 log units), on the high side; the measured number falls inside the stated range.
By their numbers in this assay, from the lowest: compounds 4, 3 and 2 (each within the scatter of the next). At a limit, above all of these: compound 1.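

On the terminal urea aryl ring, at the carbon ortho to a chloro group, trifluoromethyl in place of chloro gives an at least 7.2-fold lower number from compound 1 to compound 4 (0.86 log units; beyond the scatter) in this assay. Among the compounds shown here, this is the first single-place step, and it shows that this position alone can separate a measurable compound from one at a limit. Compound 1 is held at a limit, so the full size of the step stays open: the limit of > 32500 nM in this assay, at which 1 of the 4 values shown sits.

From the compounds shown here alone, whether a nitrile or a methyl group at this position would give a similar number remains open. So does whether the same swap would act alike on a different core.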